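The compounds below may be only part of what the source reports. "The series", "measured", "known", "first", "only" and "open" are said of these compounds alone.

Values so far in a physicochemical assay for solubility, read by HPLC; a higher number here means a more soluble compound, a lower number a less soluble compound:
- compound 1 `O=C(c1ccc(Cl)cc1)N1CCN(c2nc(=O)c3cc(C(F)(F)F)cc([N+](=O)[O-])c3s2)CC1`: 5.19 ug/mL
- compound 2 `Cc1ccc(C(=O)N2CCN(c3nc(=O)c4cc(C(F)(F)F)cc([N+](=O)[O-])c4s3)CC2)cc1`: 6.7 ug/mL
- compound 3 `CCC(C)C(=O)N1CCN(c2nc(=O)c3cc(C(F)(F)F)cc([N+](=O)[O-])c3s2)CC1`: 104 ug/mL

Compound 3 stands highest of the three, at 104 ug/mL, and its gaps to both others are beyond the scatter. Two measured steps reach it, a 20-fold higher number from compound 1 to compound 3 (1.30 log units; beyond the scatter) and a 16-fold higher number from compound 2 to compound 3 (1.19 log units; beyond the scatter), both large, and each puts sec-butyl in place of an aromatic group on a carbonyl carbon. The third step, methyl in place of chloro, is a 1.3-fold higher number from compound 1 to compound 2 (0.11 log units; within the scatter) and stays within the scatter.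

Next is compound 4 `CC(C)CC(=O)N1CCN(c2nc(=O)c3cc(C(F)(F)F)cc([N+](=O)[O-])c3s2)CC1`, with isobutyl in place of sec-butyl on a carbonyl carbon. The two have the same atoms, joined differently. Within the data shown here, no measured step exchanges one open chain for another, so the data bear on this change only indirectly. The large steps, such as a 16-fold higher number from compound 2 to compound 3 (1.19 log units; beyond the scatter), involved the loss of an aromatic group, and nothing of that kind happens here. Among the measured compounds shown here, the one small step, a 1.3-fold higher number from compound 1 to compound 2 (0.11 log units; within the scatter), is the nearest guide in size, and no step beyond the scatter is expected in this assay.

The expected change is a 1.2-fold lower number from compound 3 to compound 4 (0.06 log units; within the scatter), with a slight lean downward at most. For compound 4 the estimated value is 90 ug/mL, with an expected range from 45 ug/mL to 180 ug/mL.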

Compound 4, solubility: 66.3 ug/mL
Compound 4: middle estimate off by 1.4-fold (0.13 log units), on the high side; low and high end bracket the measured number.
By their numbers in this assay, from the lowest: compounds 1 and 2 (each within the scatter of the next); then compounds 4 and 3 (each within the scatter of the next).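

In this assay, exchanging sec-butyl for isobutyl on the carbonyl carbon gives a step within the scatter (a 1.6-fold lower number from compound 3 to compound 4 (0.20 log units; within the scatter)), so this exchange between the two open chains leaves the number little moved. The high numbers are also not confined to sec-butyl: isobutyl too stands clear of both aromatic groups (a 9.9-fold higher number from compound 2 to compound 4 (1.00 log units; beyond the scatter); a 13-fold higher number from compound 1 to compound 4 (1.11 log units; beyond the scatter)), the first step printed as modest and the second as large, and among the four compounds shown, neither open-chain compound goes against this. No measurement at hand bears on what lies behind these steps.

Still open, on these data alone, is whether the high numbers belong to open chains in general or simply to groups without an aromatic ring, a question that cyclohexyl on the carbonyl carbon would address when set against the 4-methylphenyl and isobutyl compounds. Also open, as far as these compounds go, is how far the number holds with a shorter chain such as ethyl, a longer chain such as n-hexyl, or a chain carrying an amine or a carboxylic acid.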